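The source may report more compounds than this note shows. Statements on the series, on what has been measured and on what is new or still open speak of the compounds shown alone.

Measured in a functional assay on ECa-109 cells for inhibition, with ECa-109 cell line (Homo sapiens) as the target, read by sulforhodamine B assay; a lower number here means a stronger inhibitor, a higher number a weaker inhibitor:
- Compound 1 `O=C1C(Nc2ccccc2F)=CC(=O)c2c1nc1n2[C@H]2OC[C@@H](O)[C@H]2OC1`: 2660 nM
- Compound 2 `CCc1ccc(NC2=CC(=O)c3c(nc4n3[C@H]3OC[C@@H](O)[C@H]3OC4)C2=O)cc1`: > 4000 nM (a limit of the assay, not a number)

Compound 2 has no exact value and stands only at a limit: the limit of > 4000 nM in this assay, at which 1 of the 2 values shown sits. Compound 3 `Cc1ccc(NC2=CC(=O)c3c(nc4n3[C@H]3OC[C@@H](O)[C@H]3OC4)C2=O)cc1` has hydrogen in place of methyl on a saturated chain carbon bound to an aromatic carbon, turning 4-ethylphenyl into 4-methylphenyl. For the measured compounds named here, the only measured step nearby is a different change, an at least 1.5-fold higher number from compound 1 to compound 2 (0.17 log units; that floor lies within the scatter). It gives no sign of a large effect, so no shift beyond the scatter is expected in this assay. The expected step is an at least 1.1-fold lower number from compound 2 to compound 3 (0.04 log units; that floor lies within the scatter). For compound 3 the estimated value is 3600 nM, with an expected range of 1800 nM to 7000 nM.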

Compound 3, half-maximal inhibitory concentration: > 4000 nM
Compound 3: a limit, no number (the forecaster's own chance of this, stated with the estimate: 45%); middle value at least 1.1-fold (0.04 log units) away from the limit.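

In this assay, compound 3 stands at a limit of the assay, not at a number, as compound 2 does, so the change from 4-ethylphenyl to 4-methylphenyl cannot be read. For the compounds shown here, the one readable step is an at least 1.5-fold higher number from compound 1 to compound 3 (0.17 log units; that floor lies within the scatter), so replacing 2-fluorophenyl with 4-methylphenyl on the amine nitrogen shows no change beyond the scatter. The limit now covers most of the set: the limit of > 4000 nM in this assay, at which 2 of the 3 values shown sit.

As far as these compounds go, whether compound 2 and compound 3 truly differ from compound 1 stays open. So does whether a plain phenyl or a 4-methoxyphenyl group on that nitrogen would give a number in this assay.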